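Cytotoxicity Outlook for an Octyl Hydrazone Analogue

This account rests on a few compounds, and the source may have more. Where it says the series, first, only, none or still open, it means among the compounds named here.

Compound 3 `CN(C)C(=O)C[C@H](CSc1ccccc1)Nc1c(C(=O)N/N=C/c2ccc(OC(F)(F)F)cc2)cnc2ccc(F)cc12` has been measured in an ADME assay on Vero cells (Chlorocebus sabaeus) for cytotoxicity, read by MTT assay, with a stated time of 72 h; a higher number here means a weaker inhibitor, a lower number a stronger inhibitor. In this assay compound 3 gives only a limit, > 62.5 ug/mL. Compound 1 `CN(C)C(=O)C[C@H](CSc1ccccc1)Nc1c(C(=O)N/N=C/c2ccccc2F)cnc2c(C(F)(F)F)cccc12` also gives a limit in this assay, > 62.5 ug/mL. Compound 2 `CN(C)C(=O)C[C@H](CSc1ccccc1)Nc1c(C(=O)N/N=C/c2ccc(OC(F)(F)F)cc2)cnc2c(C(F)(F)F)cccc12` likewise gives a limit, > 62.5 ug/mL. Among the compounds with values here, the single measured step, a step that the two limits leave unreadable from compound 1 to compound 2, is unreadable for that reason, and the limit of > 62.5 ug/mL in this assay, at which 3 of the 3 values shown sit, shows that every measured value rests at that limit. Compound 4 `CCCCCCCC/C=N/NC(=O)c1cnc2ccc(F)cc2c1N[C@@H](CSc1ccccc1)CC(=O)N(C)C` differs from compound 3 by octyl in place of 4-(trifluoromethoxy)phenyl on a carbon with a double bond to nitrogen. Within the data shown here, no measured step involves an octyl group, so the step of a number no higher from compound 3 to compound 4 (the limit leaves the size open) is expected to be none beyond the scatter. Compound 4 is estimated at 62.5 ug/mL, within 30 ug/mL to 125 ug/mL, most probably again reported only as a limit.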

Compound 4, half-maximal inhibitory concentration: > 62.5 ug/mL
Compound 4: no number, only a limit (the forecaster's own chance of this, stated with the estimate: 70%); the middle value sits exactly at the limit.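

No step can be read between compound 3 and compound 4, as both give only a limit in this assay. The compounds shown leave open how they differ in this assay, because every value rests at one limit: the limit of > 62.5 ug/mL in this assay, at which 4 of the 4 values shown sit.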